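The source may report more compounds than this note shows. Statements on the series, on what has been measured and on what is new or still open speak of the compounds shown alone.

Compound 3 `CCc1ccc(SCc2ccc(C(=O)Nc3ccccc3N)cc2)cc1` is the most active of three measured compounds in a functional assay on SMMC-7721 cells (Homo sapiens) for inhibition, read by CCK-8 assay, with a stated time of 72 h, tested at 8 uM (on this read-out higher numbers stand for more inhibition of growth at the one concentration tested and lower numbers for less inhibition of growth), where compound 3 gives 82.9%. Compound 2 `CCc1ccc(SCc2ccc(/C=C/C(=O)Nc3ccccc3N)cc2)cc1` carries the same 4-ethylphenyl on a sulfur but a different core; in this assay compound 2 gives 19.5%. The difference between the two cores is not broken down here. Compound 1 `Nc1ccccc1NC(=O)/C=C/c1ccc(CSc2cccc(F)c2)cc1` differs from compound 2 by 3-fluorophenyl in place of 4-ethylphenyl on a sulfur, and in this assay compound 1 gives 8.25%, so that a number 11.3 percentage points lower from compound 2 to compound 1 (beyond the scatter). Compound 4 `Nc1ccccc1NC(=O)c1ccc(CSc2cccc(F)c2)cc1` carries the same change on the core of compound 3: 3-fluorophenyl in place of 4-ethylphenyl on a sulfur. Because a number 11.3 percentage points lower from compound 2 to compound 1 (beyond the scatter), a modest drop from compound 3 is expected for compound 4 as well. Compound 4 is estimated to give 70% in this assay, expected to lie between 50% and 85%, which means an expected step of a number 12.9 percentage points lower from compound 3 to compound 4 (beyond the scatter).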

Compound 4, percent growth inhibition at one concentration: 83%
For compound 4 the middle estimate is 13 percentage points below the measured one, and the stated range covers the measured number.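

On the core of compound 3, 3-fluorophenyl in place of 4-ethylphenyl on a sulfur gives in this assay a number 0.1 percentage points higher from compound 3 to compound 4 (within the scatter). Set beside the same change on the core of compound 2, the two steps cannot be told apart: the same change on two cores in this assay, a number 11.3 percentage points lower (beyond the scatter) from compound 2 to compound 1 and a number 0.1 percentage points higher (within the scatter) from compound 3 to compound 4, 11.4 percentage points apart, within the scatter of two such steps. This shows no measurable dependence of the change on the core, but it does not prove that the change carries over identically, as it rests on one pair per core at a single concentration.

From the compounds shown here alone, it remains open how a phenyl bearing an amine or a carboxylic acid on the sulfur would behave on these two cores. The same holds for a longer chain in place of either aryl group.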